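The source may report more compounds than this note shows. Statements on the series, on what has been measured and on what is new or still open speak of the compounds shown alone.

Compounds measured so far in an ADME assay on isolated protein for pharmacokinetics, with UDP-glucuronosyltransferase 1A9 (Homo sapiens) as the target, read by LC-MS, with a stated time of 60 min, at 37 degrees C, tested at 1 uM, in the presence of a further agent that is not named here; on this read-out higher numbers stand for a longer-lived compound and lower numbers for a shorter-lived compound:

compound 1, `NS(=O)(=O)NCCSc1nonc1/C(=N/O)Nc1ccc(F)c(Br)c1`: 0.183 h
compound 2, `NS(=O)(=O)CC(=O)NCCSc1nonc1/C(=N/O)Nc1ccc(F)c(C(F)F)c1`: > 3 h
compound 3, `O=C(NCCSc1nonc1/C(=N/O)Nc1ccc(F)c(C(F)F)c1)C1CS(=O)(=O)C1`: > 3 h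

Among the compounds with values here, compound 1 carries the only true number here. For compound 2 the value is a limit of the assay, not a number. For compound 3 the value is likewise a limit. Within the data shown here, both of those sit at the limit of > 3 h in this assay, at which 2 of the 3 values shown sit, so the one single-place step that could be computed, a step that the two limits leave unreadable from compound 2 to compound 3, stays unreadable; it swaps a group of 6 heavy atoms (3 carbon, 2 oxygen, 1 sulfur; one four-membered non-aromatic ring with 1 hetero atom) for a group of 5 heavy atoms on a carbonyl carbon, and says nothing about the size of any effect.

The new compound, compound 4, `CS(=N)(=O)CC(=O)NCCSc1nonc1/C(=N/O)Nc1ccc(F)c(Br)c1`, differs from compound 1 by a group of 7 heavy atoms (3 carbon, 1 nitrogen, 2 oxygen, 1 sulfur; no ring) in place of a group of 4 heavy atoms (1 nitrogen, 2 oxygen, 1 sulfur; no ring), on an amine nitrogen. Among the measured compounds shown here, no measured step covers this change: no pair among compounds 1, 2 and 3 differs in that place alone, and compound 1 is the only reference with a number. All that can be said is that compound 1 stands short-lived and the two other values are at the limit.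

The step from compound 1 is therefore expected to be upward, a 4.9-fold higher number from compound 1 to compound 4 (0.69 log units; beyond the scatter), but with wide uncertainty. Compound 4 is estimated at 0.9 h, within 0.2 h to 3 h.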

Compound 4, half-life: 1.53 h
Compound 4: middle estimate off by 1.7-fold (0.23 log units), on the low side; measured number inside the range.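

In this assay, the amine nitrogen with the saturated chain carbon as its other neighbour proves to be a place where the half-life responds to the group it carries: exchanging sulfamoyl for the group of 7 heavy atoms gives an 8.4-fold higher number from compound 1 to compound 4 (0.92 log units; beyond the scatter) while the rest of the molecule stays the same. Within the data shown here, this is the first step whose size can be read, and it gives a second true number, so the effect of a change at this nitrogen can now be sized rather than only bounded. Neither the leaving nor the entering group has a ring or a net charge, so this rise occurs without a ring or a charge being introduced at this place, although nothing shown gives a reason for it.

The values of compound 2 and compound 3 are limits of the assay, so the step between them cannot be read and their sulfonyl-bearing groups cannot be ranked. From the compounds shown here alone, whether a simple amine, a carboxylic acid or a longer chain on the same nitrogen would shift the half-life further stays open, as does whether this exchange would act alike with difluoromethyl in place of bromine on the core.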